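Heteroaryl swap from compound 2 to compound 3

This account rests on a few compounds, and the source may have more. Where it says the series, first, only, none or still open, it means among the compounds named here.

Measured so far:
compound 1 (`Cc1cc(-c2ncccn2)cc(C(=O)NNS(=O)(=O)c2ccccc2)c1F`) gives 50 ug/mL
compound 2 (`Cc1cc(-c2ccccn2)cc(C(=O)NNS(=O)(=O)c2ccccc2)c1F`) gives 50 ug/mL

For the measured compounds named here, in a physicochemical assay for solubility, read by nephelometry, measured as kinetic solubility, at pH 2 (a lower number here means a less soluble compound, a higher number a more soluble compound), compound 2 sits at 50 ug/mL and stands level with compound 1, the only other compound measured so far. The next compound, compound 3 (`Cc1cc(-n2nccn2)cc(C(=O)NNS(=O)(=O)c2ccccc2)c1F`), carries 2H-1,2,3-triazol-2-yl in place of pyridin-2-yl on an aromatic carbon, para to a fluoro group and meta to a methyl group.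

Going by the values given here, one measured step bears on this change (no change at the digits printed from compound 1 to compound 2 (within the scatter)), where pyridin-2-yl replaces pyrimidin-2-yl at the same place. Among the compounds with values here, that step links two six-membered rings, and no measured compound has a five-membered ring here, so it is limited guidance for compound 3. Within the data shown here, with that single step as the only evidence, the expected result is no change at the digits printed from compound 2 to compound 3 (within the scatter) in this assay, with no direction favoured and nothing expected beyond the scatter. In this assay the estimated value for compound 3 is 50 ug/mL (25 ug/mL to 100 ug/mL), a range kept wide for the new ring type.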

Compound 3, solubility: 25 ug/mL
For compound 3 the middle estimate is 2.0-fold (0.30 log units) above the measured one; low and high end bracket the measured number.
By their numbers in this assay, from the lowest: compounds 3, 1 and 2 (each within the scatter of the next).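

In this assay, the step from a six-membered to a five-membered aromatic ring at this position is a 2.0-fold lower number from compound 2 to compound 3 (0.30 log units; within the scatter), and measured against the pyrimidin-2-yl group it is a 2.0-fold lower number from compound 1 to compound 3 (0.30 log units; within the scatter). Both steps stay within the scatter, so the three aromatic rings seen at this place, including 2H-1,2,3-triazol-2-yl with its five heavy atoms and three hetero atoms, cannot be told apart by this read-out, and none of the three compounds goes against that reading. Nothing measured here gives a property of these rings that could be tied to the numbers, so no explanation can be attached to the result.

The compounds shown cover only aromatic rings joined to the shared core at this aromatic carbon, so it remains open whether an amine, a carboxylic acid or a short alkyl chain in the same place would give a step beyond the scatter. The methyl and fluoro groups and the phenyl sulfonyl end are the same throughout, which leaves open whether the flat reading at this position would hold with a different group at any of those places.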